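Smaller amine on the shared core, similar weak inhibition expected

The source may hold more compounds than are shown below. What is called first, only, known or untested is meant among the compounds shown, and "the series" means these compounds.

In a functional assay on MCF7 cells (Homo sapiens) for cytotoxicity, read by sulforhodamine B assay, with a stated time of 48 h (a lower number here means a stronger inhibitor of growth, a higher number a weaker inhibitor of growth), compound 1 `O=C1C(=O)N(CN2CCCCC2)c2cccc(Cl)c21` gives 51200 nM, and compound 2 `CCN(CC)CN1C(=O)C(=O)c2c(Cl)cccc21` gives 34100 nM. For the measured compounds named here, compound 2 therefore holds the lower of the two numbers so far, but its nearest neighbour, compound 1, stands within the scatter, and the single measured step of a 1.5-fold lower number from compound 1 to compound 2 (0.18 log units; within the scatter) does not separate the two beyond what repeated measurements would show.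

Compound 3 `CN(C)CN1C(=O)C(=O)c2c(Cl)cccc21` is not yet measured in this assay. It differs from compound 2 in one place: dimethylamino in place of diethylamino on a saturated chain carbon bound to an amide-type nitrogen in a ring. Going by the values given here, the only measured step that bears on this change is the one from compound 1 to compound 2, where the amine on that same carbon was exchanged, and it was small. With nothing else to go on, the expectation is that trimming the amine further leaves the number where compound 2 sits, with no step beyond the scatter in either direction.

The step of a 1.2-fold higher number from compound 2 to compound 3 (0.07 log units; within the scatter) is thus expected to be small. Compound 3 is accordingly estimated at 40000 nM, with a likely range from 15000 nM to 110000 nM.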

Compound 3, concentration for 50% growth inhibition: 87800 nM
Estimate against measurement, compound 3: 2.2-fold (0.34 log units) below, and the stated range covers the measured number.
By their numbers in this assay, from the lowest: compounds 2, 1 and 3 (each within the scatter of the next, the first and the last beyond it).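

In this assay, for the compounds shown here, the amine on the saturated chain carbon bound to an amide-type nitrogen in a ring now shows a measurable effect on the number: a 2.6-fold higher number from compound 2 to compound 3 (0.41 log units; beyond the scatter) is the first step at this place to pass beyond the scatter, though it remains modest, and it goes with replacing diethylamino, 5 heavy atoms, by dimethylamino, 3 heavy atoms. The exchange of piperidin-1-yl for dimethylamino gives a 1.7-fold higher number from compound 1 to compound 3 (0.23 log units; within the scatter), so that pair cannot be told apart, and of the three amines only diethylamino and dimethylamino are separated, while all three compounds stay in the same weak range of growth inhibition. Nothing measured here offers an explanation for the gap between compound 2 and compound 3.

As far as these compounds go, whether a pyrrolidin-1-yl or morpholin-4-yl group on the same carbon would fall nearer compound 2 or compound 3 remains open, as does the effect of a longer amine such as dipropylamino. From the compounds shown here alone, it is also open whether the same amine exchange would give a similar step on a core carrying a fluorine or bromine in place of the chlorine.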